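Swapping the Sulfonamide Substituent for Morpholine

The compounds below may be only part of what the source reports. "The series", "measured", "known", "first", "only" and "open" are said of these compounds alone.

Of the compounds shown here, three sharing one core have been tested in a functional assay on the whole organism (trachea) with Rattus norvegicus as the target; on this read-out lower numbers stand for smaller maximal responses and higher numbers for larger maximal responses. Compound 1 `CC(C)NS(=O)(=O)c1ccc2c(c1)C(n1ccccc1=O)=CC(C)(C)O2` gives 94.8%, compound 2 `CC1(C)C=C(n2ccccc2=O)c2cc(S(=O)(=O)NCc3ccccc3)ccc2O1` gives 77.5%, and compound 3 `CC1(C)C=C(n2ccccc2=O)c2cc(S(=O)(=O)Nc3ccc(C#N)cc3)ccc2O1` gives 90.8%. Compound 3 thus stands second highest of the three, with compound 1 nearest and within the scatter, and compound 2 clearly lower. Compound 4 `CC1(C)C=C(n2ccccc2=O)c2cc(S(=O)(=O)N3CCOCC3)ccc2O1` has not been measured; it differs from compound 3 by morpholin-4-yl in place of (4-cyanophenyl)amino on a sulfonyl sulfur. The earlier changes at this same position were a number 17.3 percentage points lower from compound 1 to compound 2 (beyond the scatter), a number 4 percentage points lower from compound 1 to compound 3 (within the scatter) and a number 13.3 percentage points higher from compound 2 to compound 3 (beyond the scatter), so varied groups there shifted the response only modestly. Among the compounds with values here, no measured step covers a group of this kind, so only a small step is expected, a number 5.8 percentage points lower from compound 3 to compound 4 (within the scatter). Compound 4 is therefore estimated at 85%, within a range from 70% to 98%.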

Compound 4, largest response reached (Emax), in percent of the reference or control that the assay uses: 85.1%
For compound 4 the middle estimate is 0.1 percentage points below the measured one, and the stated range covers the measured number.
By their numbers in this assay, from the lowest: compounds 2, 4, 3 and 1 (each within the scatter of the next, the first and the last beyond it).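

Morpholin-4-yl is the first group on this sulfonyl sulfur with 0 hydrogen-bond donors, and in this assay it gives a number 5.7 percentage points lower from compound 3 to compound 4 (within the scatter), a number 7.6 percentage points higher from compound 2 to compound 4 (within the scatter) and a number 9.7 percentage points lower from compound 1 to compound 4 (within the scatter). In this single example, then, a group without the donor that the three amino groups each carry leaves the maximal response within the scatter of all three compounds. Nothing available bears on the reason for this result. Still open, from the compounds shown here alone, is whether a piperidin-1-yl ring, which has carbon in place of the morpholine oxygen, would match compound 4. Going by these compounds, a carboxylic acid or an amine on a longer chain at this sulfur also remains untested here.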